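Swapping the 2,6-dimethylpyridin-4-yl group of compound 2

A few compounds are considered here, and "the series" means these few. Any claim that something is new, unique, unknown or untested is made for them only; others in the source may bear on it.

In a physicochemical assay for acid dissociation, compound 1 `COc1cc2c(C(=O)N3CCN(C)CC3)n[nH]c2cc1-c1ccncc1` gives 5.3, while compound 2 `COc1cc2c(C(=O)N3CCN(C)CC3)n[nH]c2cc1-c1cc(C)nc(C)c1` gives 6.7, the higher of the two numbers. Compound 3 `COc1cc2c(C(=O)N3CCN(C)CC3)n[nH]c2cc1-c1ccnc(C)c1F` differs from compound 2 in one place: a group of 8 heavy atoms (6 carbon, 1 nitrogen, 1 fluorine; one six-membered aromatic ring with 1 hetero atom) in place of a group of 8 heavy atoms (7 carbon, 1 nitrogen; one six-membered aromatic ring with 1 hetero atom), on an aromatic carbon. Within the data shown here, the only measured step, a number 1.40 log units higher from compound 1 to compound 2 (beyond the scatter), was large and concerns the same aromatic carbon. Among the measured compounds shown here, no measured step involves fluorine, so it offers only partial guidance. Judged from the structural change, a large move to a lower number is expected, with an estimated step of a number 2.70 log units lower from compound 2 to compound 3 (beyond the scatter). For compound 3 the estimate is 4, with an expected range of 3.4 to 4.8.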

Compound 3, acid dissociation constant: 3.7
Beside the measured number, compound 3's estimate is 0.30 log units above it; low and high end bracket the measured number.
By their numbers in this assay, from the lowest: compound 3; then compound 1; then compound 2.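

In this assay, this aromatic carbon now shows a fall as well as a rise: the change gives a number 3.00 log units lower from compound 2 to compound 3 (beyond the scatter), and the same group set against pyridin-4-yl gives a number 1.60 log units lower from compound 1 to compound 3 (beyond the scatter). Among these compounds, the group at this place can therefore carry the number to either side of the pyridin-4-yl value, which the single earlier step could not show. Nothing available explains why the number moves this way. The compounds shown leave open how much of the fall goes with the fluorine and how much with the changed methyl pattern. From the compounds shown here alone, whether a chlorine atom in place of the fluorine would give a similar number also stays open.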